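Chloro for Fluoro on a Bis-Arylidene Cyclohexanone Scaffold

A few compounds are considered here, and "the series" means these few. Any claim that something is new, unique, unknown or untested is made for them only; others in the source may bear on it.

Three compounds built on a shared core were examined for lipophilicity, and a fourth awaits measurement. Compound 1 `O=C1/C(=C/c2ccc(F)cc2)CCC/C1=C\c1cccc([N+](=O)[O-])c1` gives 5.06 in a physicochemical assay for lipophilicity; on this read-out lower numbers stand for lower lipophilicity and higher numbers for higher lipophilicity. Compound 2 `O=C1/C(=C/c2ccc(F)cc2)CCC/C1=C\c1ccc([N+](=O)[O-])cc1` gives 5.08 in this assay. Compound 3 `O=C1/C(=C/c2ccc(Cl)cc2)CCC/C1=C\c1ccc([N+](=O)[O-])cc1` gives 5.08 in this assay. Compound 1 and compound 2 are built from the same atoms joined differently; the difference between their two cores is not broken down here, and their two values lie within the scatter of each other.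

Compound 2 and compound 3 differ in one place, (chloro in place of fluoro on an aromatic carbon), and this change produced no change at the digits printed from compound 2 to compound 3 (within the scatter).

Compound 4 `O=C1/C(=C/c2ccc(Cl)cc2)CCC/C1=C\c1cccc([N+](=O)[O-])c1` has not yet been measured in this assay. It differs from compound 1 by chloro in place of fluoro on an aromatic carbon, the same change as that from compound 2 to compound 3, and the place is described in the same words for both pairs. Among the compounds shown this change occurs twice in all.

For compound 4 the step from compound 1 is expected to be a number 0.02 log units higher from compound 1 to compound 4 (within the scatter), resting on the earlier step of no change at the digits printed from compound 2 to compound 3 (within the scatter) and the value of compound 1 5.06. Compound 4 is therefore estimated at 5.08 in this assay, with a range from 4.8 to 5.35.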

Compound 4, partition coefficient: 5.06
Compound 4: middle estimate off by 0.02 log units, on the high side; the measured number falls inside the stated range.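

In this assay the swap from 4-fluorophenyl to 4-chlorophenyl on the core of compound 1 gave no change at the digits printed from compound 1 to compound 4 (within the scatter) and thus agreed with the same swap on the core of compound 2, which gave no change at the digits printed from compound 2 to compound 3 (within the scatter) in the same read-out, so in these two pairs the change carried from one core to the other without a step beyond the scatter. Among the compounds shown here, this does not amount to a rule: it rests on only two pairs whose cores are built from the same atoms joined differently, and a step within the scatter shows only that no difference between fluoro and chloro could be read here, not that none exists. The compounds shown offer no independent measurement that bears on why these steps take the size they do.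

The compounds shown leave open whether the swap would carry equally well to a core in which the nitro group gives way to an amine or a carboxylic acid. They also leave open what would follow if a bromo group or a longer chain took the place of fluoro or chloro on the same aromatic carbon.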